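Amide to sulfonamide swap on the linker of compound 1

The source may report more compounds than this note shows. Statements on the series, on what has been measured and on what is new or still open speak of the compounds shown alone.

compound 1 `O=C(NCCNc1nccc(-c2c(-c3cccc(F)c3)nc3sccn23)n1)c1c(F)cccc1F`: 11400 nM in a functional assay on SK-MEL-28 cells (Homo sapiens) for cytotoxicity, read by MTT assay; on this read-out higher numbers stand for weaker inhibition and lower numbers for stronger inhibition
compound 2 `O=C(NCCNc1nccc(-c2c(-c3cccc(F)c3)nc3sccn23)n1)c1ccc(Cl)cc1`: 8160 nM in this assay

Within the data shown here, compound 1 gives the highest of the two numbers so far in this assay; its nearest neighbour is compound 2, and the change a 1.4-fold lower number from compound 1 to compound 2 (0.15 log units; within the scatter) lies within the scatter. Compound 3 `Cc1ccc(S(=O)(=O)NCCCNc2nccc(-c3c(-c4cccc(F)c4)nc4sccn34)n2)cc1` differs from compound 1 by (((4-methylphenyl)sulfonyl)amino)methyl in place of ((2,6-difluorophenyl)carbonyl)amino on a saturated chain carbon, two bonds along the chain from a nitrogen on an aromatic ring. Among the measured compounds shown here, no measured step touches a sulfonamide or a lengthened chain; the only step at hand, a 1.4-fold lower number from compound 1 to compound 2 (0.15 log units; within the scatter), exchanges one aryl group on the carbonyl carbon for another and gives no shift beyond the scatter. Whether the group on the chain matters at all cannot be told from that single step. The expected step of a 1.2-fold lower number from compound 1 to compound 3 (0.08 log units; within the scatter) is therefore small in this assay, with no clear direction. Compound 3 is estimated at 9500 nM in this assay, within 3000 nM to 30000 nM.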

Compound 3, half-maximal inhibitory concentration: 9500 nM
For compound 3 middle estimate and measured number coincide at the digits printed; measured number inside the range.
By their numbers in this assay, from the lowest: compounds 2, 3 and 1 (each within the scatter of the next).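

In this assay, (((4-methylphenyl)sulfonyl)amino)methyl in place of ((2,6-difluorophenyl)carbonyl)amino gives a 1.2-fold lower number from compound 1 to compound 3 (0.08 log units; within the scatter), and the same group in place of ((4-chlorophenyl)carbonyl)amino gives a 1.2-fold higher number from compound 2 to compound 3 (0.07 log units; within the scatter). The earlier step exchanged only the aryl group on the carbonyl carbon, whereas these steps replace the carbonyl with a sulfonyl and extend the group by a methyl unit, and on this saturated chain carbon neither step goes beyond the scatter. No measurement is available that would explain this result.

Because the sulfonyl and the added methyl enter together, their separate contributions remain unresolved. On these data alone, all three compounds end in an aryl group, so it remains open whether a primary amine, a carboxylic acid or a much longer chain at this place would give a step beyond the scatter.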